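A few compounds are considered here, and "the series" means these few. Any claim that something is new, unique, unknown or untested is made for them only; others in the source may bear on it.

The series shares one core, seen in compound 1 `N#CC1=C(N)N(c2ccc(S(N)(=O)=O)cc2)C2=C(C(=O)CCC2)C1c1ccccc1`, compound 2 `N#CC1=C(N)N(c2ccc(S(N)(=O)=O)cc2)C2=C(C(=O)CCC2)C1c1ccc(O)cc1` and compound 3 `COc1ccccc1C1C(C#N)=C(N)N(c2ccc(S(N)(=O)=O)cc2)C2=C1C(=O)CCC2`; the three differ only in the aryl group on a saturated ring carbon. In a functional assay on Ehrlich cells (Mus musculus) for antiproliferative activity, read by trypan blue exclusion, with a stated time of 2 h, tested at 50 ug/mL (on this read-out higher numbers stand for a stronger effect at the one concentration tested and lower numbers for a weaker effect), compound 1 gives 40%, compound 2 gives 100% and compound 3 gives 0%. Compound 3 thus stands lowest of the three: a number 40 percentage points lower from compound 1 to compound 3 (beyond the scatter) and a number 100 percentage points lower from compound 2 to compound 3 (beyond the scatter), both beyond the scatter. Compound 4 `N#CC1=C(N)N(c2ccc(S(N)(=O)=O)cc2)C2=C(C(=O)CCC2)C1c1cccc([N+](=O)[O-])c1` is not yet measured. The change from compound 3 to compound 4 is 3-nitrophenyl in place of 2-methoxyphenyl on a saturated ring carbon. Among the compounds with values here, two measured steps touch the group that leaves: a number 40 percentage points lower from compound 1 to compound 3 (beyond the scatter) sets the methoxy group against hydrogen, and a number 100 percentage points lower from compound 2 to compound 3 (beyond the scatter) sets 2-methoxyphenyl against 4-hydroxyphenyl. Within the data shown here, no measured compound carries a nitro group, so the weight of the entering 3-nitrophenyl is unknown. Taking away the 2-methoxyphenyl alone would, by the step from compound 1, point back toward the level of compound 1; whether 3-nitrophenyl adds to or subtracts from that cannot be read from the numbers. Compound 4 is therefore expected to land near the level of compound 1. The expected step is a number 40 percentage points higher from compound 3 to compound 4 (beyond the scatter). The estimate for compound 4 in this assay is 40%, within 0% to 80%, the range kept wide for want of any nitro-bearing comparator.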

Compound 4, a percentage reported as activity, at one concentration (the size of the read-out at that concentration, not a potency): 73%
Compound 4: middle estimate off by 33 percentage points, on the low side; the range from low to high includes it.
By their numbers in this assay, from the lowest: compound 3; then compound 1; then compound 4; then compound 2.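

In this assay, within the data shown here, the aryl group on the saturated ring carbon gains from a nitro substituent, with a number 33 percentage points higher from compound 1 to compound 4 (beyond the scatter) as the step for nitro in place of hydrogen, so compound 2 is no longer the only compound above compound 1, while compound 3 still goes the other way. The exchange of 2-methoxyphenyl for 3-nitrophenyl gives a number 73 percentage points higher from compound 3 to compound 4 (beyond the scatter) and thus exceeds the gap set by the methoxy step alone, a number 40 percentage points lower from compound 1 to compound 3 (beyond the scatter) in the opposite direction, which shows that the entering group has weight of its own and that the change is more than the loss of the 2-methoxyphenyl. The 4-hydroxyphenyl group nevertheless keeps its lead, as 3-nitrophenyl in its place gives a number 27 percentage points lower from compound 2 to compound 4 (beyond the scatter) and leaves compound 2 the highest of the four.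

Nothing at hand explains these differences. On these data alone, because the substituent and its place on the aryl ring change together across these compounds, it remains open which of the two governs the read-out at this single concentration, and how an aminophenyl or a carboxyphenyl group would rank against 4-hydroxyphenyl and 3-nitrophenyl.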